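The source may hold more compounds than are shown below. What is called first, only, known or untested is meant among the compounds shown, and "the series" means these compounds.

For the measured compounds named here, in a functional assay on B16 cells (Mus musculus) for cytotoxicity, read by CCK-8 assay, with a stated time of 24 h (a higher number here means a weaker inhibitor, a lower number a stronger inhibitor), compound 2 (`COc1ccccc1Oc1c(N)nc(-c2ccc(Br)cc2)nc1Cl`) gives 4440 nM, the lower of the two numbers so far, while compound 1 (`COc1ccc(-c2nc(N)c(Oc3ccccc3OC)c(Cl)n2)cc1`) gives 47800 nM. Going by the values given here, the only measured step, an 11-fold lower number from compound 1 to compound 2 (1.03 log units; beyond the scatter), is large and came with bromo in place of methoxy on an aromatic carbon. Compound 3 (`COc1ccccc1Oc1c(N)nc(-c2cccc(I)c2)nc1Cl`) carries 3-iodophenyl in place of 4-bromophenyl (3-iodophenyl in place of 4-bromophenyl on an aromatic carbon). Among the compounds with values here, the measured step bears on this only loosely, as no measured compound carries iodo. A much smaller change, not clearly beyond the scatter, is expected: a 1.3-fold lower number from compound 2 to compound 3 (0.10 log units; within the scatter). Compound 3 is estimated at 3500 nM, with an expected range of 1300 nM to 11000 nM.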

Compound 3, half-maximal inhibitory concentration: 27600 nM
The estimate for compound 3 lay 7.9-fold (0.90 log units) below the measured number, outside the stated range (above it).
By their numbers in this assay, from the lowest: compound 2; then compounds 3 and 1 (each within the scatter of the next).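

With 3-iodophenyl in place of 4-bromophenyl on this aromatic carbon, the step of a 6.2-fold higher number from compound 2 to compound 3 (0.79 log units; beyond the scatter) shows that a halogen on the phenyl does not by itself keep the lower number. The step of a 1.7-fold lower number from compound 1 to compound 3 (0.24 log units; within the scatter) leaves 3-iodophenyl and 4-methoxyphenyl indistinguishable at this position. No available evidence bears on this result.

Since both the halogen and its place on the phenyl differ between compound 2 and compound 3, the compounds shown do not separate the two. On these data alone, what a phenyl carrying an amine or a carboxylic acid would give also stays open.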